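Removing the chloro group: what to expect for compound 4

This account rests on a few compounds, and the source may have more. Where it says the series, first, only, none or still open, it means among the compounds named here.

Measured compounds in a functional assay on MDA-MB-231 cells (Homo sapiens) for antiproliferative activity, read by MTT assay, with a stated time of 48 h; on this read-out higher numbers stand for weaker inhibition and lower numbers for stronger inhibition:
compound 1 `COC(=O)/C(=C/c1ccccc1)CN1C(=O)[C@@H](OC)[C@H]1c1ccc(Cl)cc1` gives 15600 nM
compound 2 `CCOC(=O)/C(=C/c1ccccc1)CN1C(=O)[C@@H](OC)[C@H]1c1ccc(F)cc1` gives 14000 nM
compound 3 `CO[C@@H]1C(=O)N(C/C(C#N)=C/c2ccccc2)[C@@H]1c1ccc(Cl)cc1Cl` gives 17000 nM

Compound 1 holds the second highest of the three numbers, yet its gaps to compound 3 and to compound 2 both lie within the usual scatter, so the three compounds cannot be told apart on potency. Compound 4 `COC(=O)/C(=C/c1ccccc1)CN1C(=O)[C@@H](OC)[C@H]1c1ccccc1` differs from compound 1 in one place: hydrogen in place of chloro on an aromatic carbon. Within the data shown here, no measured pair shows this change on its own, so its effect is not known from the data. The three measured values sit close together. Only a small step, if any beyond the scatter, is expected for this change in this assay, leaning toward a slightly higher number. Compound 4 is therefore estimated at 20000 nM, within a range of 8000 nM to 50000 nM. The expected step is a 1.3-fold higher number from compound 1 to compound 4 (0.11 log units; within the scatter).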

Compound 4, half-maximal inhibitory concentration: 11100 nM
Compound 4: middle estimate off by 1.8-fold (0.26 log units), on the high side, within the range that was stated.
By their numbers in this assay, from the lowest: compounds 4, 2, 1 and 3 (each within the scatter of the next).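

Taking the chloro off the aromatic carbon para to a large group gives a 1.4-fold lower number from compound 1 to compound 4 (0.15 log units; within the scatter) in this assay. This single-place comparison shows that, in this core, the chloro is not needed to keep activity at this level, since the phenyl compound cannot be told apart from its 4-chlorophenyl partner. Nothing measured here bears on why this is so.

On these data alone, whether an amine or a carboxylic acid at this position would shift the number beyond the scatter stays open. As far as these compounds go, it is also open whether a longer chain there would do so.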